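The source may hold more compounds than are shown below. What is called first, only, known or untested is meant among the compounds shown, and "the series" means these compounds.

Series notes on a functional assay on MGC-803 cells (Homo sapiens) for inhibition, read by sulforhodamine B assay; on this read-out higher numbers stand for weaker inhibition and lower numbers for stronger inhibition. Compound 1 `O=C1C=C(NC2CCCCC2)C(=O)c2c1nc1n2[C@H]2OC[C@@H](O)[C@H]2OC1` carries a cyclohexylamino group on the shared core. In this assay compound 1 gives only a limit, > 8000 nM. Compound 3 `O=C1C=C(N2CCCCC2)C(=O)c2c1nc1n2[C@H]2OC[C@@H](O)[C@H]2OC1` carries piperidin-1-yl in the same place on the core. In this assay compound 3 likewise gives only a limit, > 8000 nM. Within the data shown here, compound 2 `CCOc1ccccc1NC1=CC(=O)c2nc3n(c2C1=O)[C@H]1OC[C@@H](O)[C@H]1OC3` carries 2-ethoxyphenyl on the amine nitrogen, and in this assay compound 2 gives 2450 nM, the only number in the set so far. Among the measured compounds shown here, the step of an at least 3.2-fold lower number from compound 1 to compound 2 (0.51 log units; beyond the scatter) is the one readable step. The step that the two limits leave unreadable from compound 1 to compound 3 cannot be read because the limit of > 8000 nM in this assay, at which 2 of the 3 values shown sit, holds both ends of it. So compound 3 stands at the limit together with compound 1, and nothing places it relative to compound 1.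

Compound 4 `COc1ccccc1NC1=CC(=O)c2nc3n(c2C1=O)[C@H]1OC[C@@H](O)[C@H]1OC3` is not yet measured in this assay. The change from compound 3 is (2-methoxyphenyl)amino in place of piperidin-1-yl on a double-bonded ring carbon. Compound 4 is therefore close in build to compound 2, sharing the arylamino group on the double-bonded ring carbon, with methoxy in place of ethoxy. For the measured compounds named here, the step of an at least 3.2-fold lower number from compound 1 to compound 2 (0.51 log units; beyond the scatter) is the only guide; the step from a piperidin-1-yl to an arylamino group has no measured counterpart. From the limit of compound 3 the expected step of an at least 3.2-fold lower number from compound 3 to compound 4 (0.50 log units; beyond the scatter) is a lowering whose size cannot be fixed. Compound 4 is expected near compound 2, at 2500 nM, within 1000 nM to 8000 nM.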

Compound 4, half-maximal inhibitory concentration: 1630 nM
Beside the measured number, compound 4's estimate is 1.5-fold (0.19 log units) above it; the measured number falls inside the stated range.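

In this assay, the change to (2-methoxyphenyl)amino on the double-bonded ring carbon gives an at least 4.9-fold lower number from compound 3 to compound 4 (0.69 log units; beyond the scatter), so a change at this position away from piperidin-1-yl can now be read as a lowering. The second arylamino compound also gives an at least 4.9-fold lower number from compound 1 to compound 4 (0.69 log units; beyond the scatter), which repeats against the cyclohexylamino compound what the 2-ethoxyphenyl group showed; among these four compounds, only the two with an aryl group on the amine nitrogen give numbers, and none goes against this. Methoxy and ethoxy cannot be told apart, since a 1.5-fold lower number from compound 2 to compound 4 (0.18 log units; within the scatter) gives no order between the two compounds.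

The true sizes of the steps from compound 1 and compound 3 stay unfixed, and the step between those two compounds cannot be read, because each of them gives only a limit: the limit of > 8000 nM in this assay, at which 2 of the 4 values shown sit. The compounds shown also leave open how a plain phenylamino group or a benzylamino group would read at this position, so the part played by the alkoxy group and by the direct link of the aromatic ring to the amine nitrogen remains unresolved.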